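The source may report more compounds than this note shows. Statements on the series, on what has been measured and on what is new or still open speak of the compounds shown alone.

Compound 1 `COc1ccc(-n2c(=O)c(C(=O)Nc3ccc(Oc4ccnc5[nH]ccc45)cc3)cc3cccnc32)cc1` in a functional assay on A549 cells (Homo sapiens) for antiproliferative activity, read by MTT assay, with a stated time of 72 h (a higher number here means a weaker inhibitor, a lower number a stronger inhibitor), gives 930 nM. Compound 2 `O=C(Nc1ccc(Oc2ccnc3[nH]ccc23)cc1)c1cc2cccnc2n(-c2ccc(F)c(Cl)c2)c1=O` differs from it by 3-chloro-4-fluorophenyl in place of 4-methoxyphenyl on an aromatic nitrogen, and in this assay compound 2 gives 680 nM, a step of a 1.4-fold lower number from compound 1 to compound 2 (0.14 log units; within the scatter). Compound 3 `COc1ccc(-n2c(=O)c(C(=O)Nc3ccc(Oc4ccnc5[nH]ccc45)c(F)c3)cc3cccnc32)cc1` stands on a second core, which differs from the core of compound 1 by fluoro in place of hydrogen on an aromatic carbon; in this assay compound 3 gives 610 nM, a step of a 1.5-fold lower number from compound 1 to compound 3 (0.18 log units; within the scatter). All three numbers fall within the scatter of one another, so none of the three can be set apart from the others on this evidence.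

Compound 4 `O=C(Nc1ccc(Oc2ccnc3[nH]ccc23)c(F)c1)c1cc2cccnc2n(-c2ccc(F)c(Cl)c2)c1=O` has not yet been measured. It differs from compound 3 by 3-chloro-4-fluorophenyl in place of 4-methoxyphenyl on an aromatic nitrogen, the same change that was made between compound 1 and compound 2, at the same place on the shared core. The step expected in this assay is a 1.4-fold lower number from compound 3 to compound 4 (0.13 log units; within the scatter), set beside the earlier step, because a 1.4-fold lower number from compound 1 to compound 2 (0.14 log units; within the scatter) was small and the two cores differ only by the fluoro. For compound 4 the estimate in this assay is 450 nM, with a range from 200 nM to 1000 nM.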

Compound 4, half-maximal inhibitory concentration: 630 nM
Compound 4: the middle estimate sits 1.4-fold (0.15 log units) below what was measured, and the stated range covers the measured number.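

In this assay, 3-chloro-4-fluorophenyl in place of 4-methoxyphenyl on the aromatic nitrogen gives a 1.0-fold higher number from compound 3 to compound 4 (0.01 log units; within the scatter), and fluoro in place of hydrogen on an aromatic carbon gives a 1.1-fold lower number from compound 2 to compound 4 (0.03 log units; within the scatter). The change on the aromatic nitrogen reads alike on the two cores, with no difference that can be told apart: the same change on two cores in this assay, a 1.4-fold lower number (0.14 log units; within the scatter) from compound 1 to compound 2 and a 1.0-fold higher number (0.01 log units; within the scatter) from compound 3 to compound 4, 1.4-fold (0.15 log units) apart, within the scatter of two such steps. Within the data shown here, the fluoro change reads the same way, but since every one of these steps lies within the scatter, this shows only that neither change moved the number measurably on either core, not that a real effect of either change carries over from one core to another: the same change on two cores in this assay, a 1.5-fold lower number (0.18 log units; within the scatter) from compound 1 to compound 3 and a 1.1-fold lower number (0.03 log units; within the scatter) from compound 2 to compound 4, 1.4-fold (0.15 log units) apart, within the scatter of two such steps.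

The compounds shown leave open whether a different group on the aromatic nitrogen, such as a phenyl ring bearing an amine or a carboxylic acid, or a longer alkyl chain, would give a step beyond the scatter. They also leave open whether chloro in place of the fluoro on the aromatic carbon would read the same way.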